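A few compounds are considered here, and "the series" means these few. Any claim that something is new, unique, unknown or untested is made for them only; others in the source may bear on it.

Measured in an ADME assay on A549 cells (Homo sapiens) for cytotoxicity, read by CellTiter-Glo; on this read-out higher numbers stand for lower toxicity in this test and lower numbers for higher toxicity in this test:
compound 1 `Cc1c(Cc2ccc(F)cc2)c(=O)oc2cc(OCC(O)CN3CCC(C(N)=O)CC3)ccc12` — 89300 nM
compound 2 `Cc1c(Cc2cccc(F)c2)c(=O)oc2cc(OCC(O)CN3CCC(C(N)=O)CC3)ccc12` — 53300 nM
compound 3 `Cc1c(Cc2ccccc2C(F)(F)F)c(=O)oc2cc(OCC(O)CN3CCC(C(N)=O)CC3)ccc12` — > 100000 nM, which is a limit of the assay and not a number.

Compound 1 gives the highest of the two numbers; the nearest, compound 2, lies a 1.7-fold lower number from compound 1 to compound 2 (0.22 log units; within the scatter). Placing 2-(trifluoromethyl)phenyl on the saturated chain carbon bound to an aromatic carbon gives an at least 1.8-fold higher number from compound 2 to compound 3 (0.27 log units; that floor lies within the scatter) and an at least 1.1-fold higher number from compound 1 to compound 3 (0.04 log units; that floor lies within the scatter); compound 3 sits at the limit of > 100000 nM in this assay, at which 1 of the 3 values shown sits. Compound 4 `Cc1c(Cc2ccc(-c3ccc(C(F)(F)F)cc3)cc2)c(=O)oc2cc(OCC(O)CN3CCC(C(N)=O)CC3)ccc12` carries 4-(trifluoromethyl)phenyl in place of fluoro on an aromatic carbon. The three measured steps bear on it only as exchanges of the aryl group on that chain carbon, and each stayed within the scatter, though the change to compound 4 is larger than any of them. No step beyond the scatter is expected in this assay, with a wide margin allowed. Compound 4 is estimated at 60000 nM, between 20000 nM and 150000 nM, which is expected to mean a 1.5-fold lower number from compound 1 to compound 4 (0.17 log units; within the scatter).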

Compound 4, half-maximal cytotoxic concentration: > 100000 nM
Compound 4: only a limit was reported; the forecaster's own chance of this, stated with the estimate: 25%; at least 1.6-fold (0.22 log units) between middle value and limit.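

In this assay compound 4 gives > 100000 nM, which is a limit of the assay and not a number. The step to 4-(trifluoromethyl)phenyl on this aromatic carbon reads an at least 1.1-fold higher number from compound 1 to compound 4 (0.04 log units; that floor lies within the scatter), so this position carries a second aromatic ring, a far larger change than the earlier aryl exchanges, without a lower number appearing. How far the step really runs cannot be read: the limit of > 100000 nM in this assay, at which 2 of the 4 values shown sit.

The compounds shown leave open how an amine or a carboxylic acid at this position would read. They also leave open whether a smaller group such as methoxy would differ from fluoro.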